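The source may hold more compounds than are shown below. What is called first, only, known or untested is meant among the compounds shown, and "the series" means these compounds.

Compounds measured so far in an ADME assay on MT4 cells (Homo sapiens) for cytotoxicity, read by MTT assay, with a stated time of 4 days; on this read-out higher numbers stand for lower toxicity in this test and lower numbers for higher toxicity in this test:

compound 1, `Cc1cc(C#N)cc(C)c1Oc1ccnc(S(=O)(=O)CC(=O)Nc2ccccc2)n1`: 29300 nM
compound 2, `Cc1cccc(NC(=O)CS(=O)(=O)c2nccc(Oc3c(C)cc(C#N)cc3C)n2)c1`: 25700 nM
compound 3, `Cc1cc(C#N)cc(C)c1Oc1ccnc(S(=O)(=O)CC(=O)Nc2ccccc2Cl)n1`: 12500 nM

Compound 1 holds the highest of these three numbers in this assay. Compound 2 sits nearest to it, the step being a 1.1-fold lower number from compound 1 to compound 2 (0.06 log units; within the scatter), so the two are not separated. Compound 3 sits furthest from it, and the step of a 2.3-fold lower number from compound 1 to compound 3 (0.37 log units; beyond the scatter) is a modest one beyond the scatter; the step of a 2.1-fold lower number from compound 2 to compound 3 (0.31 log units; beyond the scatter) is of similar size.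

Compound 4, `Cc1cc(C#N)cc(C)c1Oc1ccnc(S(=O)(=O)CC(=O)Nc2cc(Cl)cc(Cl)c2)n1`, has not yet been measured in this assay. It differs from compound 1 in one place: 3,5-dichlorophenyl in place of phenyl on an amide-type nitrogen.

The step that bears on this change most directly is a 2.3-fold lower number from compound 1 to compound 3 (0.37 log units; beyond the scatter), where a single chloro enters on the same phenyl, and it lowered the number modestly. The change to 3,5-dichlorophenyl brings two chloro atoms, so the account expects a step in this assay of at least that size and in the same direction, a lower number. Compound 4 is therefore estimated at 9000 nM, with a range from 4000 nM to 20000 nM, which means an expected step of a 3.3-fold lower number from compound 1 to compound 4 (0.51 log units; beyond the scatter).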

Compound 4, half-maximal cytotoxic concentration: 24000 nM
Compound 4: middle estimate off by 2.7-fold (0.43 log units), on the low side, and the stated range ends below it.
By their numbers in this assay, from the lowest: compounds 3, 4, 2 and 1 (each within the scatter of the next, the first and the last beyond it).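

In this assay, 3,5-dichlorophenyl on the amide-type nitrogen is not separated from phenyl, the step being a 1.2-fold lower number from compound 1 to compound 4 (0.09 log units; within the scatter), so carrying two chlorine atoms on this ring does not by itself move the number beyond the scatter. The comparisons with the other two anilides agree, with a 1.1-fold lower number from compound 2 to compound 4 (0.03 log units; within the scatter) and a 1.9-fold higher number from compound 3 to compound 4 (0.28 log units; within the scatter) both within the scatter, which means that compound 3 is separated from compound 1 and compound 2 but not from compound 4, and the chlorine count alone does not order these compounds at this position. No measurement at hand explains why the 2-chlorophenyl and 3,5-dichlorophenyl changes differ in their steps from compound 1.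

For the compounds shown here, the four compounds leave open whether the step to compound 3 is tied to where its single chloro sits on the ring, as no compound here separates the place of a chloro from the number of chloro atoms. They also leave open what a methoxy group, an amine or a carboxylic acid on this phenyl would do in this assay, since the ring here carries only hydrogen, methyl or chloro.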